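Replacing a chlorophenyl with a methoxyphenyl on the ring amine

The source may report more compounds than this note shows. Statements on the series, on what has been measured and on what is new or still open speak of the compounds shown alone.

Measured so far:
- Compound 1, `COc1ccc(CNC(=O)C(C)c2ccc(CC(C)C)cc2)cc1O`: 18000 nM
- Compound 2, `CC(C)Cc1ccc(C(C)C(=O)N2CCN(c3cccc(Cl)c3)CC2)cc1`: 1700 nM

Both compounds were tested in an assay on brain for inhibition of Fatty-acid amide hydrolase 1 (Rattus norvegicus), read by scintillation counting, with a stated time of 10 min; a lower number here means a stronger inhibitor, a higher number a weaker inhibitor. Of the two numbers, compound 2 holds the lowest; compound 1 sits higher, a gap beyond the usual scatter. Compound 3, `COc1ccc(N2CCN(C(=O)C(C)c3ccc(CC(C)C)cc3)CC2)cc1`, has not yet been measured. It differs from compound 2 in one place: 4-methoxyphenyl in place of 3-chlorophenyl on an amine nitrogen in a ring, on an amine nitrogen in a ring of a six-membered non-aromatic ring with two nitrogens. Among the measured compounds shown here, no measured pair shows this exact exchange, so the size of the step has to be guessed. A modest weakening seems the more likely outcome, with a step of a 2.4-fold higher number from compound 2 to compound 3 (0.37 log units; beyond the scatter) expected. Compound 3 is therefore estimated at 4000 nM in this assay, in a range from 1200 nM to 15000 nM.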

Compound 3, half-maximal inhibitory concentration: 4500 nM
Compound 3: the middle estimate sits 1.1-fold (0.05 log units) below what was measured; the range from low to high includes it.
By their numbers in this assay, from the lowest: compound 2; then compound 3; then compound 1.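

Swapping the group on the ring amine is the first change in a single place among these compounds, and in this assay it gives a 2.6-fold higher number from compound 2 to compound 3 (0.42 log units; beyond the scatter), so what this nitrogen carries does affect the reading, though the step is modest. The swap alters two things at once: the substituent on the phenyl ring and the number in its name, with 4-methoxyphenyl also counting 1 hydrogen-bond acceptor where 3-chlorophenyl counts 0. Nothing available explains the size or direction of this step.

These compounds cannot separate the effect of the substituent from that of its location on the phenyl ring; 3-methoxyphenyl and 4-chlorophenyl would be the matching groups for that comparison. Also open, going by these compounds, is how a plain phenyl or a trifluoromethyl-bearing phenyl would read at this nitrogen.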